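The source may report more compounds than this note shows. Statements on the series, on what has been measured and on what is new or still open speak of the compounds shown alone.

Of the compounds shown here, three with the same core have been measured in a functional assay on FM3A cells (Mus musculus) for inhibition; a lower number here means a stronger inhibitor, a higher number a weaker inhibitor. Compound 1 `C/C(=C\COC(=O)NC(C)(C)C)C1=CC(=O)C(C)(C)O1` gives 7.1 ug/mL. Compound 2 `CCCCNC(=O)OC/C=C(\C)C1=CC(=O)C(C)(C)O1` gives 7.7 ug/mL, and compound 3 `C/C(=C\C=C/C1CCCCC1)C1=CC(=O)C(C)(C)O1` gives 10.8 ug/mL. For the measured compounds named here, the one single-point comparison available, a 1.1-fold higher number from compound 1 to compound 2 (0.04 log units; within the scatter), shows that exchanging one carbon group for another on the amide-type nitrogen left the number essentially unchanged. Compound 2 stands with its nearest neighbour being compound 1 and its most distant being compound 3, and all three numbers lie within the scatter of one another, so none of them can be called stronger or weaker than the rest.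

Compound 4 `C/C(=C\COC(=O)NC1CCCCC1)C1=CC(=O)C(C)(C)O1` carries the change (cyclohexyl in place of butyl on an amide-type nitrogen). Going by the values given here, the only measured step that touches the same position is the one from compound 1 to compound 2, and it stayed within the scatter. Compound 3 carries a cyclohexyl elsewhere and is not linked to compound 2 by a single change, so only its value speaks. On this basis the expected step is a 1.0-fold lower number from compound 2 to compound 4 (0.01 log units; within the scatter), that is, no movement beyond the scatter. Compound 4 is therefore estimated in this assay at 7.5 ug/mL, within a range of 3.5 ug/mL to 16 ug/mL.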

Compound 4, half-maximal inhibitory concentration: 13 ug/mL
Compound 4: middle estimate off by 1.7-fold (0.24 log units), on the low side; the measured number falls inside the stated range.
By their numbers in this assay, from the lowest: compounds 1, 2, 3 and 4 (each within the scatter of the next).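

In this assay, placing a cyclohexyl group on the amide-type nitrogen gives a 1.7-fold higher number from compound 2 to compound 4 (0.23 log units; within the scatter) and, measured against the tert-butyl group, a 1.8-fold higher number from compound 1 to compound 4 (0.26 log units; within the scatter). Until now this position had been tested only with open-chain groups, butyl and tert-butyl; compound 4 extends the comparison to a six-membered non-aromatic ring of carbon only, and compound 1, compound 2 and compound 4 still remain within the scatter of one another, so this assay does not separate these three groups on that nitrogen. No supporting measurement is available that could account for these numbers or tie them to any property of the groups.

The compounds shown leave open whether a phenyl ring, a longer chain such as octyl, or a chain ending in an amine or a carboxylic acid on this nitrogen would shift the number beyond the scatter. They also leave open what would happen if a methyl group took the place of the amide hydrogen, or if the carbamate link itself gave way to a plain amide.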